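Trading oxan-4-yl for morpholin-4-yl

The source may hold more compounds than are shown below. What is called first, only, known or untested is meant among the compounds shown, and "the series" means these compounds.

Of the compounds shown here, two have been measured so far in an ADME assay on microsomes from liver (Homo sapiens) for metabolic stability, read by LC-MS, with a stated time of 60 min, tested at 1 uM; a lower number here means that the compound disappears faster, a higher number that the compound lasts longer. Compound 1 (`COc1ccccc1OCCCC1CCOCC1`) gives 0.301 h, and compound 2 (`COc1ccccc1OCCOC1CCOCC1`) gives 1.39 h. Compound 2 thus holds the higher of the two numbers, and its gap to compound 1 lies beyond the scatter of repeated measurements.

Compound 3 (`COc1ccccc1OCCON1CCOCC1`) departs from compound 2 in one place: morpholin-4-yl in place of oxan-4-yl on an oxygen on a saturated carbon. Morpholin-4-yl stands in place of oxan-4-yl on an oxygen on a saturated carbon. Both groups are six-membered non-aromatic rings with no net charge.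

Among the measured compounds shown here, the measured compounds offer no step of this kind, so the expectation has no direct precedent. It rests on compound 2 at 1.39 h, the closest measured structure. In this assay, a slight fall that stays within the scatter is expected, rather than a clear move in either direction. The estimated change is a 1.3-fold lower number from compound 2 to compound 3 (0.10 log units; within the scatter). Compound 3 is expected at 1.1 h, with an estimated range of 0.45 h to 2.6 h.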

Compound 3, half-life in the Homo sapiens assay: 1.64 h
Compound 3: middle estimate off by 1.5-fold (0.17 log units), on the low side; the range from low to high includes it.
By their numbers in the Homo sapiens assay, from the lowest: compound 1; then compounds 2 and 3 (each within the scatter of the next).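

In the Homo sapiens assay, compound 2 gives 1.39 h and compound 3 gives 1.64 h; morpholin-4-yl in place of oxan-4-yl on an oxygen on a saturated carbon gives a 1.2-fold higher number from compound 2 to compound 3 (0.07 log units; within the scatter), so at this position the two six-membered rings cannot be told apart, although the entering ring carries a ring nitrogen as its second hetero atom. In a physicochemical assay for solubility, in phosphate buffer, at pH 7.4 (on this read-out lower numbers stand for lower solubility and higher numbers for higher solubility), compound 2 gives 275000 nM and compound 3 gives 293000 nM; the same exchange gives a 1.1-fold higher number from compound 2 to compound 3 (0.03 log units; within the scatter), so this read-out does not separate the two rings either, and for this pair the exchange leaves both measurements within their scatter. Nothing at hand accounts for either reading.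

The compounds shown leave open whether this holds for a ring with the nitrogen but without the ring oxygen, such as piperidin-1-yl, or for an open-chain amine such as dimethylamino on the same oxygen. They also leave open whether the match between the two rings would survive a carboxylic acid or a longer chain in this place, since a single step at one position says nothing about other groups there or about other cores.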